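Methylation of the phenol oxygen in a pyrazole series

The source may report more compounds than this note shows. Statements on the series, on what has been measured and on what is new or still open speak of the compounds shown alone.

Compound 1 `O=C(Nc1cccc(-n2cc(-c3ccncc3)c(-c3ccc(Cl)c(O)c3)n2)c1)Nc1ccc(Cl)c(Cl)c1` carries a hydroxy group and, in a functional assay on 786-0 cells (Homo sapiens) for inhibition, read by sulforhodamine B assay, with a stated time of 48 h (on this read-out higher numbers stand for weaker inhibition of growth and lower numbers for stronger inhibition of growth), compound 1 gives 7220 nM, the highest of the three numbers. Compound 2 `COc1cc(-c2nn(-c3cccc(NC(=O)c4cccc(C(F)(F)F)c4)c3)cc2-c2ccncc2)ccc1Cl` gives 2450 nM and compound 3 `COc1cc(-c2nn(-c3cccc(NC(=O)Nc4ccc(Cl)c(C(F)(F)F)c4)c3)cc2-c2ccncc2)ccc1Cl` gives 1610 nM; both carry a methoxy group but differ from compound 1 in more than one place. Among the compounds with values here, the only single-point step measured, a 1.5-fold lower number from compound 2 to compound 3 (0.18 log units; within the scatter), concerns the urea and does not bear on the change here. Compound 4 `COc1cc(-c2nn(-c3cccc(NC(=O)Nc4ccc(Cl)c(Cl)c4)c3)cc2-c2ccncc2)ccc1Cl` arises from compound 1 by the change (methyl in place of hydrogen on an oxygen on an aromatic ring). Compound 3 is its nearest measured neighbour, so a step in the direction of a 3.6-fold lower number from compound 1 to compound 4 (0.56 log units; beyond the scatter) is expected. In this assay compound 4 is estimated at 2000 nM, with a range from 800 nM to 5000 nM.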

Compound 4, concentration for 50% growth inhibition: 1310 nM
Estimate against measurement, compound 4: 1.5-fold (0.18 log units) above, and the stated range covers the measured number.
By their numbers in this assay, from the lowest: compounds 4, 3 and 2 (each within the scatter of the next); then compound 1.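

Replacing hydrogen with methyl on the oxygen gives, in this assay, a 5.5-fold lower number from compound 1 to compound 4 (0.74 log units; beyond the scatter) and so isolates this change in a single step, with hydroxy to methoxy as the only difference. Changing the other end of the molecule moves the number much less: a 1.2-fold lower number from compound 3 to compound 4 (0.09 log units; within the scatter) and a 1.9-fold lower number from compound 2 to compound 4 (0.27 log units; within the scatter) both stay within the scatter. Nothing available explains the step from hydroxy to methoxy.

Going by these compounds, it remains open whether an ethoxy group, a longer chain on the oxygen, or an amine in place of the hydroxy group would give a similar number. The step is also read on only one urea, the 3,4-dichlorophenyl one.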